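Aryl swap at the ring nitrogen: expected cytotoxicity

This account rests on a few compounds, and the source may have more. Where it says the series, first, only, none or still open, it means among the compounds named here.

Compound 1 `CC(C)(C)c1ccc(-n2nc(-c3ccc(C(F)(F)F)cc3O)nc2-c2ccccc2O)cc1`: 77.8%
Compound 2 `Oc1cc(C(F)(F)F)ccc1-c1nc(-c2ccccc2O)n(-c2ccc(OC(F)(F)F)cc2)n1`: 84.9%

In a functional assay on PC-12 cells (Rattus norvegicus) for cytotoxicity, read by MTT assay, with stated times of 2 h and 24 h, tested at 5 uM (on this read-out lower numbers stand for a weaker effect and higher numbers for a stronger effect at the one concentration tested), compound 1 gives 77.8%, the lower of the two numbers, and compound 2 gives 84.9%. Among the measured compounds shown here, the single measured step, trifluoromethoxy in place of tert-butyl on an aromatic carbon, was a number 7.1 percentage points higher from compound 1 to compound 2 (within the scatter). Compound 3 `Oc1cc(C(F)(F)F)ccc1-c1nc(-c2ccccc2O)n(-c2cc(F)cc(F)c2)n1` differs from compound 1 by 3,5-difluorophenyl in place of 4-(tert-butyl)phenyl on an aromatic nitrogen. For the measured compounds named here, that change also replaces the 4-(tert-butyl)phenyl, so the step from compound 1 to compound 2 is the only guide, and it suggests no move beyond the scatter. Compound 3 is therefore expected to give 80%, between 66% and 92%, a step of a number 2.2 percentage points higher from compound 1 to compound 3 (within the scatter).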

Compound 3, a percentage reported as activity, at one concentration (the size of the read-out at that concentration, not a potency): 100%
Estimate against measurement, compound 3: 20 percentage points below, and the stated range ends below it.
By their numbers in this assay, from the lowest: compounds 1 and 2 (each within the scatter of the next); then compound 3.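

On the aromatic nitrogen of the five-membered ring, the choice of aryl group can move the read-out beyond the scatter in this assay, which the step between the two earlier compounds did not show. Putting 3,5-difluorophenyl in place of 4-(tert-butyl)phenyl gives a number 22.2 percentage points higher from compound 1 to compound 3 (beyond the scatter), and putting it in place of 4-(trifluoromethoxy)phenyl gives a number 15.1 percentage points higher from compound 2 to compound 3 (beyond the scatter), so compound 3 stands apart from both. Nothing measured here accounts for this difference.

As far as these compounds go, it remains open whether both fluorines are needed for this step, and how a phenyl group carrying an amine or a carboxylic acid would read at this nitrogen.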